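The source may hold more compounds than are shown below. What is called first, only, known or untested is meant among the compounds shown, and "the series" means these compounds.

Measured so far:
compound 1 `CNc1nc(C)c(C(=O)N/N=C/c2ccccc2C(F)(F)F)s1` — > 100 ug/mL (a functional assay on HepG2 cells (Homo sapiens) for inhibition, read by MTT assay, with a stated time of 72 h; a lower number here means a stronger inhibitor, a higher number a weaker inhibitor)
compound 2 `CN(C(=O)NC(=O)c1ccc(F)c(F)c1)c1nc(C(F)(F)F)c(C(=O)N/N=C/c2ccccc2C(F)(F)F)s1` — 10.4 ug/mL
compound 3 `CN(C(=O)NC(=O)c1ccccc1F)c1nc(C(F)(F)F)c(C(=O)N/N=C/c2ccccc2C(F)(F)F)s1` — 5.39 ug/mL

Compound 1 gives only a limit of the assay, (the limit of > 100 ug/mL in this assay, at which 1 of the 3 values shown sits). Compound 3 has the lowest number of the two numeric values; its nearest neighbour is compound 2, and the step of a 1.9-fold lower number from compound 2 to compound 3 (0.29 log units; within the scatter) lies within the scatter. Compound 4 `CNc1nc(C(F)(F)F)c(C(=O)N/N=C/c2ccccc2C(F)(F)F)s1` is not yet measured. It differs from compound 3 by hydrogen in place of ((2-fluorophenyl)carbonyl)carbamoyl on a nitrogen on an aromatic ring. Going by the values given here, no measured step covers removal of the whole ((2-fluorophenyl)carbonyl)carbamoyl group; the only measured step, between compound 2 and compound 3, exchanges one aryl ring for another and lies within the scatter. Compound 1, which also lacks this group, shows only a limit. Compound 4 is therefore expected to give a much higher number, 80 ug/mL (range 30 ug/mL to 200 ug/mL), a step of a 15-fold higher number from compound 3 to compound 4 (1.17 log units; beyond the scatter) that is estimated, with a real chance of a limit only.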

Compound 4, half-maximal inhibitory concentration: > 100 ug/mL
Compound 4 was reported as a limit; the forecaster's own chance of this, stated with the estimate: 55%; middle value at least 1.2-fold (0.09 log units) away from the limit.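

Going by these compounds alone, replacing the ((2-fluorophenyl)carbonyl)carbamoyl group on this nitrogen with hydrogen gives an at least 18-fold higher number from compound 3 to compound 4 (1.26 log units; beyond the scatter), the first step at this position that lies beyond the scatter. Compound 4 stands at a limit of the assay, as does compound 1: the limit of > 100 ug/mL in this assay, at which 2 of the 4 values shown sit.
The step of trifluoromethyl in place of methyl on the aromatic carbon cannot be read from these two limits. The compounds shown leave open whether the whole group is needed or only part of it, which a plain carbamoyl or an acetyl on this nitrogen would address. Also open, on these data alone, is whether methyl in place of trifluoromethyl matters when the nitrogen carries the full group.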